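A few compounds are considered here, and "the series" means these few. Any claim that something is new, unique, unknown or untested is made for them only; others in the source may bear on it.

Of the compounds shown here, three have been measured in an assay on membranes from HEK293 cells for displacement of a labelled ligand from adenosine receptor A2b (Homo sapiens), read by scintillation counting, with a stated time of 30 min, tested at 1 uM; on this read-out higher numbers stand for more inhibition at the one concentration tested (going by the name of the read-out) and lower numbers for less inhibition. Compound 3 `CC1=C(C(=O)OCC(C)C)C(c2cccs2)NC(=O)N1C` gives 2%, the lowest of the three numbers. Compound 2 `COC(=O)C1=C(C)N(C)C(=O)NC1c1cccs1` gives 17%, and compound 1 `CC1=C(C(=O)OCc2ccccc2)C(c2ccoc2)NC(=O)N1C` gives 49%; both sit beyond the scatter above compound 3.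

Among the compounds with values here, only one measured step changes a single place: a number 15 percentage points lower from compound 2 to compound 3 (beyond the scatter), where isopropyl replaces hydrogen on a saturated chain carbon bound to an oxygen next to a carbonyl group. Lengthening the ester chain in that way lowered the number modestly.

Compound 4 `CC1=C(C(=O)OCc2ccccc2)C(c2cccs2)NC(=O)N1C` differs from compound 3 by a single change: phenyl in place of isopropyl on a saturated chain carbon bound to an oxygen next to a carbonyl group. Within the data shown here, it alters the same place as the one measured step, but that step swapped hydrogen for isopropyl rather than isopropyl for phenyl, so it shows that this position matters without fixing the direction for a phenyl. The ester of compound 1 also ends in a benzyl group, although compound 1 differs from compound 3 elsewhere as well; in this assay compound 1 gives 49%, which points toward a higher number for a benzyl ester.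

Compound 4 is therefore expected to give about 38%, within a range from 12% to 62%. The step this estimate implies is a number 36 percentage points higher from compound 3 to compound 4 (beyond the scatter).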

Compound 4, a percentage reported as inhibition, at one concentration (the size of the read-out at that concentration, not a potency): 50%
Estimate against measurement, compound 4: 12 percentage points below; measured number inside the range.
By their numbers in this assay, from the lowest: compound 3; then compound 2; then compounds 1 and 4 (each within the scatter of the next).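

In this assay, phenyl in place of isopropyl on a saturated chain carbon bound to an oxygen next to a carbonyl group gives a number 48 percentage points higher from compound 3 to compound 4 (beyond the scatter), so this place can carry a large upward change as well as the modest downward one seen before. Measured from the hydrogen of compound 2, the two groups pull in opposite directions: isopropyl gives a number 15 percentage points lower from compound 2 to compound 3 (beyond the scatter), while phenyl gives a number 33 percentage points higher from compound 2 to compound 4 (beyond the scatter), so adding a group here does not by itself lower the number. With the benzyl ester kept, thiophen-2-yl in place of furan-3-yl on a saturated ring carbon gives a number 1 percentage points higher from compound 1 to compound 4 (within the scatter), so this pair shows no readable difference between those two rings.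

Nothing available here accounts for why phenyl and isopropyl differ so sharply at this place. As far as these compounds go, it remains open whether a longer chain such as phenethyl, or a phenyl ring carrying a methoxy group or a chlorine atom, would hold or raise the number, and these single-concentration percentages do not give a potency for any of the compounds.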